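Dropping the methoxy from the benzyl group of compound 3

The source may report more compounds than this note shows. Statements on the series, on what has been measured and on what is new or still open speak of the compounds shown alone.

Compound 3 `COc1cccc(CN2C(=O)CN(C(=O)c3cc4cc(OC)ccc4[nH]3)C[C@@H]2Cc2ccccn2)c1` stands highest of the two numbers shown in a physicochemical assay for solubility, read by spectrophotometry, in phosphate buffer, with a stated time of 2 h, at pH 7.4; a higher number here means a more soluble compound, a lower number a less soluble compound: compound 3 gives 57900 nM. Its nearest neighbour is compound 1 `COc1ccc2[nH]c(C(=O)N3CC(=O)N(Cc4ccccc4)[C@@H](COCc4ccccc4)C3)cc2c1`, which in this assay gives 8800 nM. For compound 2 `COc1ccc2[nH]c(C(=O)N3CC(=O)N(Cc4ccccc4)[C@@H](CN4CCC(OC)CC4)C3)cc2c1` this assay reports only a limit, > 25000 nM, and not a number.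

Compound 4 `COc1ccc2[nH]c(C(=O)N3CC(=O)N(Cc4ccccc4)[C@@H](Cc4ccccn4)C3)cc2c1` differs from compound 3 in one place: hydrogen in place of methoxy on an aromatic carbon. For the measured compounds named here, no measured step touches this position. Going by the values given here, the only measured step, an at least 2.8-fold higher number from compound 1 to compound 2 (0.45 log units; beyond the scatter), concerns a different part of the molecule, where the 4-methoxypiperidin-1-yl enters in place of benzyloxy on the saturated chain carbon, and the evidence for it is a limit (the limit of > 25000 nM in this assay, at which 1 of the 3 values shown sits), so it says nothing about removing a methoxy from the aromatic ring. Among the compounds with values here, with no step bearing on the change, he expects the step of a 1.4-fold lower number from compound 3 to compound 4 (0.16 log units; within the scatter) to be small, and not beyond the scatter in either direction. His estimate for compound 4 in this assay is therefore 40000 nM, expected to lie between 15000 nM and 100000 nM.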

Compound 4, solubility: > 100000 nM
Compound 4 gave a limit, no number; the forecaster's own chance of this, stated with the estimate: 15%; at least 2.5-fold (0.39 log units) between middle value and limit.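

In this assay, for the compounds shown here, the change from 3-methoxybenzyl to benzyl, with hydrogen in place of methoxy on the aromatic carbon, gives an at least 1.7-fold higher number from compound 3 to compound 4 (0.23 log units; that floor lies within the scatter), and this is the only measured step at this position. The value of compound 4 is a limit and not a number, so the step has a floor but no known size, and that floor does not show that the position matters: the limit of > 100000 nM in this assay, at which 1 of the 4 values shown sits. With the benzyl group held constant, pyridin-2-yl in place of benzyloxy on the saturated chain carbon gives an at least 11-fold higher number from compound 1 to compound 4 (1.05 log units; beyond the scatter), a large step beyond the scatter, whereas the step between compound 2 and compound 4 cannot be read, the two values both being limits.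

The compounds shown leave open how far the true value of compound 4 lies from its limit, and so whether removing the methoxy changes the reading by more than the scatter. They also leave open what an amine, a carboxylic acid or a longer alkoxy chain such as ethoxy would do in place of the methoxy on this aromatic carbon.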